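A few compounds are considered here, and "the series" means these few. Any claim that something is new, unique, unknown or untested is made for them only; others in the source may bear on it.

Measured in a functional assay on DU-145 cells (Homo sapiens) for inhibition, read by sulforhodamine B assay, with a stated time of 72 h; a higher number here means a weaker inhibitor of growth, a lower number a stronger inhibitor of growth:
- compound 1 `C=C1CC[C@@H]2[C@](C)(COC(=O)CCCCC3CCSS3)[C@H](OC(=O)CCCCC3CCSS3)CC[C@@]2(C)[C@@H]1/C=C/C1=CCOC1=O`: 11800 nM
- compound 2 `C=C1CC[C@@H]2[C@](C)(COC(=O)C3CCCN3C(=O)OC(C)(C)C)[C@H](O)CC[C@@]2(C)[C@@H]1/C=C/C1=CCOC1=O`: 18800 nM

Within the data shown here, only these two compounds have values so far. Compound 2, at 18800 nM, lies within the usual scatter of compound 1, at 11800 nM, so the two values cannot be ranked against each other.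

Compound 3 `C=C1CC[C@@H]2[C@](C)(COC(=O)CCCCC3CCSS3)[C@H](O)CC[C@@]2(C)[C@@H]1/C=C/C1=CCOC1=O` is still to be measured in this assay. It departs from compound 2 in one place: a group of 9 heavy atoms (7 carbon, 2 sulfur; one five-membered non-aromatic ring with 2 hetero atoms) in place of a group of 12 heavy atoms (9 carbon, 1 nitrogen, 2 oxygen; one five-membered non-aromatic ring with 1 hetero atom), on a carbonyl carbon. The 1-(tert-butoxycarbonyl)pyrrolidin-2-yl group leaves, and a group with a five-membered non-aromatic ring holding two hetero atoms enters on the same carbonyl carbon.

Among the measured compounds shown here, no step between measured compounds is available as a guide, so the size of this change cannot be read from the series. The expectation rests only on the two values at hand, with compound 1 at 11800 nM and compound 2 at 18800 nM. No shift beyond the scatter is expected, and the estimated step is a 1.6-fold lower number from compound 2 to compound 3 (0.19 log units; within the scatter). The expected value for compound 3 is 12000 nM, with an estimated range of 5000 nM to 26000 nM.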

Compound 3, concentration for 50% growth inhibition: > 30000 nM
Compound 3: no number, only a limit; the forecaster's own chance of this, stated with the estimate: 7%; at least 2.5-fold (0.39 log units) between middle value and limit.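

Compound 3 gives only a limit in this assay, not a number: the limit of > 30000 nM in this assay, at which 1 of the 3 values shown sits.

On the carbonyl carbon, putting the group with the five-membered ring holding two sulfur atoms in place of the 1-(tert-butoxycarbonyl)pyrrolidin-2-yl group gives an at least 1.5-fold higher number from compound 2 to compound 3 (0.20 log units; that floor lies within the scatter), so this floor does not establish a real difference between the two groups. Among these compounds, the other change does: a hydrogen atom in place of the group of 11 heavy atoms, on the oxygen on a saturated carbon, gives an at least 2.5-fold higher number from compound 1 to compound 3 (0.40 log units; beyond the scatter), the first step beyond the scatter, and it shows that the ester on this oxygen counts for growth inhibition with the other ester held constant.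

On these data alone, it remains open whether this step depends on the ring with two sulfur atoms or would follow from any ester on that oxygen, a question that an acetyl group or an unbranched octanoyl chain there would address. As far as these compounds go, with only a limit for compound 3, the full size of both steps also remains open.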